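The source may hold more compounds than are shown below. What is called first, only, known or untested is meant among the compounds shown, and "the series" means these compounds.

In a functional assay on HL-60 cells (Homo sapiens) for antiproliferative activity, with a stated time of 72 h (a higher number here means a weaker inhibitor, a lower number a stronger inhibitor), three compounds built on a shared sugar-bearing core have been measured. Compound 1 `OC[C@H]1O[C@@H](n2cnc3c(NCc4ccc(Cl)cc4)ncnc32)[C@H](O)[C@@H]1O` gives 1700 nM, compound 2 `OC[C@H]1O[C@@H](n2cnc3c(NCc4ccccc4Br)ncnc32)[C@H](O)[C@@H]1O` gives 6600 nM, and compound 3 `COc1ccc(CNc2ncnc3c2ncn3[C@@H]2O[C@H](CO)[C@@H](O)[C@H]2O)c(OC)c1` gives 39000 nM. Compound 2 thus stands second of the three numbers, set apart by a 3.9-fold higher number from compound 1 to compound 2 (0.59 log units; beyond the scatter) and by a 5.9-fold higher number from compound 2 to compound 3 (0.77 log units; beyond the scatter), while the whole span is a 23-fold higher number from compound 1 to compound 3 (1.36 log units; beyond the scatter). Compound 4 `OC[C@H]1O[C@@H](n2cnc3c(NCc4ccc(F)cc4F)ncnc32)[C@H](O)[C@@H]1O` differs from compound 2 by 2,4-difluorophenyl in place of 2-bromophenyl on a saturated chain carbon bound to a nitrogen on an aromatic ring. Both measured steps that touch compound 2 alter this same group; the entering 2,4-difluorophenyl shares a halogen with the 4-chlorophenyl of compound 1 and the 2-bromophenyl of compound 2, whereas the 2,4-dimethoxyphenyl of compound 3 does not. A modest step toward a lower number is therefore expected, a 2.2-fold lower number from compound 2 to compound 4 (0.34 log units; beyond the scatter). In this assay compound 4 is expected to give about 3000 nM, between 1000 nM and 9000 nM.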

Compound 4, half-maximal inhibitory concentration: 3400 nM
Beside the measured number, compound 4's estimate is 1.1-fold (0.05 log units) below it; the measured number falls inside the stated range.
By their numbers in this assay, from the lowest: compounds 1, 4 and 2 (each within the scatter of the next, the first and the last beyond it); then compound 3.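

With 2,4-difluorophenyl at this place, compound 4 lies within the scatter of both other halogen-bearing compounds (a 1.9-fold lower number from compound 2 to compound 4 (0.29 log units; within the scatter); a 2.0-fold higher number from compound 1 to compound 4 (0.30 log units; within the scatter)), although those two remain apart beyond it. The large step from the 2,4-dimethoxyphenyl of compound 3 (an 11-fold lower number from compound 3 to compound 4 (1.06 log units; beyond the scatter)) shows that the weak number of compound 3 is not shared by compound 4 with its 2,4-difluorophenyl. Nothing available explains these differences. The compounds shown leave open how an amine or a carboxylic acid on the phenyl ring, or a longer chain in place of the benzyl link, would fare.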